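A (4-chlorophenyl)amino swap on the core of compound 1

The source may hold more compounds than are shown below. What is called first, only, known or untested is meant among the compounds shown, and "the series" means these compounds.

In a functional assay on A549 cells (Homo sapiens) for antiproliferative activity, read by MTT assay, with a stated time of 72 h (on this read-out higher numbers stand for weaker inhibition and lower numbers for stronger inhibition), compound 1 `COc1cc(C(=O)c2sc3ccccc3c2-c2ccc(SC)cc2)cc(OC)c1OC` gives 5400 nM. That value lies within the scatter of compound 3 `CCOc1ccc(-c2c(C(=O)c3cc(OC)c(OC)c(OC)c3)sc3ccccc23)cc1`, which gives 3100 nM. Compound 2 `COc1ccccc1-c1c(C(=O)c2cc(OC)c(OC)c(OC)c2)sc2ccccc12` returns only a limit, > 10000 nM.

The next candidate, compound 4 `COc1cc(C(=O)c2sc3ccccc3c2Nc2ccc(Cl)cc2)cc(OC)c1OC`, keeps the core of compound 1 but carries (4-chlorophenyl)amino in place of 4-(methylsulfanyl)phenyl on an aromatic carbon. The measured steps only exchange groups among the aromatic rings attached directly to the core, so none tests the new amino link. One is a 1.7-fold lower number from compound 1 to compound 3 (0.24 log units; within the scatter). Another is an at least 1.8-fold higher number from compound 1 to compound 2 (0.26 log units; that floor lies within the scatter). Only an at least 3.2-fold lower number from compound 2 to compound 3 (0.50 log units; beyond the scatter) clears the scatter, and it reaches that size from a limit. With so little to go on, the modest 1.7-fold lower number from compound 1 to compound 3 (0.24 log units; within the scatter) serves as the best guide, and no change beyond the scatter is expected in this assay. The estimated change is a 1.4-fold lower number from compound 1 to compound 4 (0.13 log units; within the scatter). For compound 4 the expected value is 4000 nM, with an estimated range of 600 nM to 10000 nM.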

Compound 4, half-maximal inhibitory concentration: 3100 nM
Compound 4: the middle estimate sits 1.3-fold (0.11 log units) above what was measured, within the range that was stated.
By their numbers in this assay, from the lowest: compounds 3, 4 and 1 (each within the scatter of the next). At a limit, above all of these: compound 2.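

On the aromatic carbon two ring bonds from the ring sulfur, the ring need not sit directly on the core. With an amino link, a chlorine and an added hydrogen-bond donor in the entering group, this assay gives a 1.7-fold lower number from compound 1 to compound 4 (0.24 log units; within the scatter) and no change at the digits printed from compound 3 to compound 4 (within the scatter), while the gap to the ortho-free comparison is absent from neither step's scatter verdict: both lie within the scatter. Against the 2-methoxyphenyl compound the picture differs, with an at least 3.2-fold lower number from compound 2 to compound 4 (0.50 log units; beyond the scatter), but compound 2 has only a limit, so that step is a floor: the limit of > 10000 nM in this assay, at which 1 of the 4 values shown sits.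

From the compounds shown here alone, the amino link and the chlorine arrive together in compound 4, so what each contributes alone stays open. A (phenyl)amino group without the chlorine, or a 4-chlorophenyl group attached directly with no amino link, would separate the two.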